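The source may hold more compounds than are shown below. What is called first, only, known or untested is meant among the compounds shown, and "the series" means these compounds.

Working notes on the series, read in an ADME assay on HEK293 cells (Homo sapiens) for cytotoxicity, read by MTT assay (on this read-out lower numbers stand for stronger inhibition and higher numbers for weaker inhibition), as the only measurement available. Compound 1 (`COc1cc2ncnc(Nc3cc(-c4ccccc4)[nH]n3)c2cc1OC`) gives 71100 nM and compound 2 (`COc1cc2ncnc(Nc3cc(-c4ccc(Cl)cc4)[nH]n3)c2cc1OC`) gives 81200 nM on the same read-out, so compound 2 sits level with compound 1 within the scatter. The next compound is compound 3 (`COc1ccc(-c2cc(Nc3ncnc4cc(OC)c(OC)cc34)n[nH]2)cc1`), which differs from compound 2 by methoxy in place of chloro on an aromatic carbon, para to a large group (methoxy in place of chloro on an aromatic carbon). Within the data shown here, only one measured step bears on this change, and it concerns the same aromatic carbon: a 1.1-fold higher number from compound 1 to compound 2 (0.06 log units; within the scatter) for chloro in place of hydrogen. Among the measured compounds shown here, that step is small, but no methoxy compound has been measured, so the reading for methoxy is indirect. For the measured compounds named here, with only that step as a guide, no change beyond the scatter is expected in this assay and no direction can be favoured. The expected move is a 1.1-fold lower number from compound 2 to compound 3 (0.03 log units; within the scatter) on this estimate. Compound 3 is estimated at 75000 nM with an expected range of 40000 nM to 130000 nM on this read-out.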

Compound 3, half-maximal inhibitory concentration: < 100000 nM
Compound 3: only a limit was reported; the forecaster's own chance of this, stated with the estimate: 10%; the middle value does not contradict the limit.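

Compound 3 is reported in this assay only as a limit, < 100000 nM. Among these compounds, no step to it from compound 1 or compound 2 can therefore be read: the limit of < 100000 nM in this assay, at which 1 of the 3 values shown sits. The compounds shown leave open whether methoxy in place of chloro or hydrogen on the aromatic carbon changes the number on this read-out.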